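Bromo to Chloro on Two Spiro Triazine Cores

The source may hold more compounds than are shown below. What is called first, only, known or untested is meant among the compounds shown, and "the series" means these compounds.

Measured compounds:
- compound 1, `NC1=NC2(CCSCC2)N(OCCCOc2ccccc2Br)C(N)=N1`: 1 nM
- compound 2, `NC1=NC2(CCOCC2)N(OCCCOc2cccc(Br)c2)C(N)=N1`: 40 nM
- compound 3, `NC1=NC2(CCSCC2)N(OCCCOc2ccccc2Cl)C(N)=N1`: 1 nM

In a functional assay on HCT-116 cells (Homo sapiens) for antiproliferative activity, read by MTT assay, with a stated time of 72 h (on this read-out higher numbers stand for weaker inhibition and lower numbers for stronger inhibition), compound 1 gives 1 nM and compound 3 gives 1 nM; the step of no change at the digits printed from compound 1 to compound 3 (within the scatter) is chloro in place of bromo on an aromatic carbon, placed ortho to a large group. Compound 2 stands highest of the three in this assay at 40 nM; how its core differs from the core of compound 1 is not broken down here. Compound 4, `NC1=NC2(CCOCC2)N(OCCCOc2cccc(Cl)c2)C(N)=N1`, is unmeasured and differs from compound 2 by chloro in place of bromo on an aromatic carbon, here meta to a large group, so the same kind of change as from compound 1 to compound 3, on another core. Because no change at the digits printed from compound 1 to compound 3 (within the scatter) lay within the scatter, the step of no change at the digits printed from compound 2 to compound 4 (within the scatter) is expected to be small as well. Compound 4 is therefore estimated at 40 nM, likely between 15 nM and 110 nM.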

Compound 4, half-maximal inhibitory concentration: 120 nM
Estimate against measurement, compound 4: 3.0-fold (0.48 log units) below, and the stated range ends below it.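

In this assay, the exchange of bromo for chloro gives a 3.0-fold higher number from compound 2 to compound 4 (0.48 log units; beyond the scatter), so on this core it is not as silent as no change at the digits printed from compound 1 to compound 3 (within the scatter). The two steps differ, and the change did not carry over unchanged from one core to the other: the same change on two cores in this assay, no change at the digits printed (within the scatter) from compound 1 to compound 3 and a 3.0-fold higher number (0.48 log units; beyond the scatter) from compound 2 to compound 4, 3.0-fold (0.48 log units) apart, beyond the scatter of two such steps. This does not show that the core alone sets the size of the step, since the halogen also sits in a different place on the aromatic ring in the two pairs, and one pair per core gives no general rule for the series.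

The compounds shown leave open how each core would respond with the halogen in the same place. They also leave open whether fluoro, methyl or methoxy at that aromatic carbon would follow either step.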